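Benzophenone aminobenzimidazoles: cytotoxicity on human cells

The source may hold more compounds than are shown below. What is called first, only, known or untested is meant among the compounds shown, and "the series" means these compounds.

Measured so far:
compound 1 `O=C(NCCO)Nc1nc2cc(C(=O)c3ccccc3)ccc2[nH]1` — > 30000 nM
compound 2 `O=C(CCC1CCNCC1)Nc1nc2ccc(C(=O)c3ccccc3)cc2[nH]1` — > 30000 nM
compound 3 `CN1CCC(Cn2c(N)nc3ccc(C(=O)c4ccccc4)cc32)CC1` — > 30000 nM

All three values are limits of the assay, not numbers. In an ADME assay on CRL8155 cells (Homo sapiens) for cytotoxicity, read by resazurin assay, with a stated time of 72 h (on this read-out lower numbers stand for an effect already at smaller amounts and higher numbers for an effect only at larger amounts of compound), compound 1 gives only a limit, > 30000 nM. Compound 2 likewise gives only a limit, > 30000 nM. Compound 3 also stands only at a limit, > 30000 nM. Among the compounds with values here, compound 3 thus stands where the other two stand: every value shown sits at the limit of > 30000 nM in this assay, at which 3 of the 3 values shown sit, and no compound can be ordered above or below another. Within the data shown here, no step between two measured compounds can be read from these data.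

Compound 4 `CC(C)(C)Cn1c(N)nc2ccc(C(=O)c3ccccc3)cc21` is not yet measured in this assay. It differs from compound 3 in one place: tert-butyl in place of 1-methylpiperidin-4-yl on a saturated chain carbon bound to an aromatic nitrogen. Among the measured compounds shown here, with no measured step to lean on, and with compound 3 at the limit, the expectation for this change in this assay is no step beyond the usual scatter, in either direction. Compound 4 is therefore expected to give about 30000 nM, within a range of 10000 nM to 100000 nM, most likely again reported only as a limit. The step from compound 3 to compound 4 that this estimate means is a number no higher from compound 3 to compound 4 (the limit leaves the size open). The expectation rests on compound 3 standing at > 30000 nM and on (the limit of > 30000 nM in this assay, at which 3 of the 3 values shown sit).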

Compound 4, half-maximal effective concentration: > 30000 nM
Compound 4: a limit, no number; the forecaster's own chance of this, stated with the estimate: 75%; the middle value lies on the limit itself.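

In this assay compound 4 stands only at a limit of the assay, not at a number (> 30000 nM). Compound 3 also stands at a limit, so no step can be read from compound 3 to compound 4: the limit of > 30000 nM in this assay, at which 4 of the 4 values shown sit.

The compounds shown leave open at what concentration any of them would reach a half-maximal effect on these cells.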